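Ethoxycarbonyl on the phenyl ring of compound 2

This account rests on a few compounds, and the source may have more. Where it says the series, first, only, none or still open, it means among the compounds named here.

Compound 1 `COc1cc(-c2ccnc3cc(-c4c[nH]c5ccccc45)nn23)cc(OC)c1OC`: 85 nM
Compound 2 `COc1cc(-c2ccnc3cc(-c4ccccc4)nn23)cc(OC)c1OC`: 254 nM
Compound 3 `COc1cc(-c2ccnc3cc(-c4cccc(C)c4)nn23)cc(OC)c1OC`: 1080 nM

These numbers come from a functional assay on MCF7 cells (Homo sapiens) for inhibition, read by CCK-8 assay, with a stated time of 48 h; on this read-out higher numbers stand for weaker inhibition and lower numbers for stronger inhibition. Compound 2 sits in the middle of the three at 254 nM, with compound 1 giving a lower number and compound 3 a higher one.

Compound 4 `CCOC(=O)c1ccc(-c2cc3nccc(-c4cc(OC)c(OC)c(OC)c4)n3n2)cc1` keeps the core of compound 2 and changes only its phenyl ring: ethoxycarbonyl in place of hydrogen on an aromatic carbon. The new ethoxycarbonyl group sits para to a large group.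

Among the measured compounds shown here, three measured steps bear on this change. Replacing the 1H-indol-3-yl of compound 1 gave a 3.0-fold higher number from compound 1 to compound 2 (0.48 log units; beyond the scatter) with phenyl and a 13-fold higher number from compound 1 to compound 3 (1.10 log units; beyond the scatter) with 3-methylphenyl, so the number does respond to changes in this group. The closest comparison is the addition of methyl to the phenyl ring, which gave a 4.3-fold higher number from compound 2 to compound 3 (0.63 log units; beyond the scatter). For the measured compounds named here, that is a single example with a different group, and no measured compound carries ethoxycarbonyl, so the guidance is limited. A modest rise in the number is therefore expected in this assay, with wide uncertainty.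

The expected step is a 2.8-fold higher number from compound 2 to compound 4 (0.44 log units; beyond the scatter). For compound 4 the estimated value is 700 nM, with an expected range from 180 nM to 3000 nM.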

Compound 4, half-maximal inhibitory concentration: > 10000 nM
Compound 4 was reported as a limit (the forecaster's own chance of this, stated with the estimate: 6%); at least 14-fold (1.15 log units) between middle value and limit.
By their numbers in this assay, from the lowest: compound 1; then compound 2; then compound 3. At a limit, above all of these: compound 4.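

In this assay compound 4 gives > 10000 nM, which is a limit of the assay and not a number. Among the compounds shown here, until now, the only change on the phenyl ring of compound 2 had left a measurable value, whereas ethoxycarbonyl in place of hydrogen, para to a large group, gives an at least 39-fold higher number from compound 2 to compound 4 (1.59 log units; beyond the scatter), against a 4.3-fold higher number from compound 2 to compound 3 (0.63 log units; beyond the scatter) for methyl on that ring. So this ring does not simply take on a new group at a modest cost, and one substituent can carry the number out of the measured range, with the true size of the step unknown because compound 4 stands at a limit: the limit of > 10000 nM in this assay, at which 1 of the 4 values shown sits.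

From the compounds shown here alone, what stays open is whether this loss belongs to ethoxycarbonyl in particular or would follow from any group at this place. A methoxy group, an amine or a carboxylic acid in the same place would help to separate the two, since each differs from ethoxycarbonyl in size or kind.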